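From a Fluorophenyl Hydrazone to a Bromo-Hydroxyphenyl Hydrazone

The source may hold more compounds than are shown below. What is called first, only, known or untested is meant among the compounds shown, and "the series" means these compounds.

Compound 1 `O=C(N/N=C/c1ccc(F)cc1)Nc1cc2c(Nc3ccc(F)c(Cl)c3)ncnc2cc1O[C@H]1CCOC1`: "not active" (no number reported)
Compound 2 `O=C(N/N=C/c1ccc(O)cc1O)Nc1cc2c(Nc3ccc(F)c(Cl)c3)ncnc2cc1O[C@H]1CCOC1`: 4530 nM
Compound 3 `COc1cc2ncnc(Nc3ccc(F)c(Cl)c3)c2cc1NC(=O)N/N=C/c1ccc(F)cc1`: 31100 nM

These three compounds share one core and differ in the aryl group hung on the hydrazone and in the ether attached to the core. All were tested in a functional assay on HepG2 cells (Homo sapiens) for cytotoxicity, read by MTT assay, with a stated time of 72 h; on this read-out higher numbers stand for weaker inhibition and lower numbers for stronger inhibition. Compound 3 gives 31100 nM, the higher of the two numbers reported and thus the weaker inhibition. Compound 2 gives 4530 nM, and the gap between these two lies beyond the usual scatter. Compound 1 gives "not active" (no number reported), so no number stands for it.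

Compound 4 `COc1cc2ncnc(Nc3ccc(F)c(Cl)c3)c2cc1NC(=O)N/N=C/c1ccc(O)c(Br)c1` has not yet been measured. It differs from compound 3 in one place: 3-bromo-4-hydroxyphenyl in place of 4-fluorophenyl on a carbon with a double bond to nitrogen. Among the compounds with values here, no pair of measured compounds shows exactly this change. Still, compound 2 carries hydroxyl groups on its aryl ring and gives 4530 nM, while the fluorophenyl compound 1 gives "not active" (no number reported). On that hint, compound 4 is expected to give about 12000 nM, with a range from 3000 nM to 40000 nM. The expected step of a 2.6-fold lower number from compound 3 to compound 4 (0.41 log units; beyond the scatter) points to a lower number, beyond the scatter, though only modestly so.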

Compound 4, half-maximal inhibitory concentration: 23800 nM
Estimate against measurement, compound 4: 2.0-fold (0.30 log units) below, and the stated range covers the measured number.
By their numbers in this assay, from the lowest: compound 2; then compounds 4 and 3 (each within the scatter of the next).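

In this assay, putting 3-bromo-4-hydroxyphenyl in place of 4-fluorophenyl on the carbon with a double bond to nitrogen gives a 1.3-fold lower number from compound 3 to compound 4 (0.12 log units; within the scatter), so the two compounds cannot be told apart on this read-out. Within the data shown here, this is the first exchange at this position in which both partners carry a number, and with the rest of the molecule held constant, an aryl ring bearing a hydroxyl group and a bromine reads the same as one bearing a fluorine. Nothing measured here explains this result.

The compounds shown leave open whether the hydroxyl group or the bromine alone would give a similar number on this ring. They also leave open how an aryl ring carrying an amine or a carboxylic acid at this position would read in this assay.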